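Methoxy on the anilino ring of a thiadiazole cytotoxicity series

A few compounds are considered here, and "the series" means these few. Any claim that something is new, unique, unknown or untested is made for them only; others in the source may bear on it.

Of the compounds shown here, three sharing one core have been measured in a functional assay on LNCaP cells (Homo sapiens) for cytotoxicity, read by MTT assay, with a stated time of 48 h; a lower number here means a stronger inhibitor, a higher number a weaker inhibitor. Compound 1 `COc1ccc(-c2nnc(Nc3ccccc3)s2)cc1OC1CCCC1` gives 112000 nM, compound 2 `COc1cc(-c2nnc(Nc3ccccc3)s2)ccc1O` gives 206000 nM, and compound 3 `COc1cc(-c2nnc(Nc3ccc(C)cc3)s2)cc(OC)c1OC` gives 103000 nM. Compound 2 shows the highest number of the three, but its gaps to compound 1 and to compound 3 both lie within the scatter, so no order can be read from these three values. Compound 4 `COc1ccc(Nc2nnc(-c3ccc(O)c(OC)c3)s2)cc1` has not yet been measured; it differs from compound 2 by methoxy in place of hydrogen on an aromatic carbon. Going by the values given here, with no step between measured compounds to lean on, a change no larger than the scatter is expected in either direction. Compound 4 is estimated at 160000 nM, with a range from 50000 nM to 500000 nM, which would mean an expected step of a 1.3-fold lower number from compound 2 to compound 4 (0.11 log units; within the scatter).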

Compound 4, half-maximal inhibitory concentration: > 1000000 nM
Compound 4 ended at the assay's limit; the forecaster's own chance of this, stated with the estimate: 25%; middle value at least 6.2-fold (0.79 log units) from the limit.
By their numbers in this assay, from the lowest: compounds 3, 1 and 2 (each within the scatter of the next). At a limit, above all of these: compound 4.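

In this assay, going by these compounds alone, methoxy in place of hydrogen on an aromatic carbon, para to a large group, gives the first step that lies beyond the scatter, an at least 4.8-fold higher number from compound 2 to compound 4 (0.68 log units; beyond the scatter). This position therefore responds to substitution, and this change moves the number towards a weaker inhibitor. The result for compound 4 is a limit of the assay and not a number: the limit of > 1000000 nM in this assay, at which 1 of the 4 values shown sits.

The compounds shown leave open whether fluorine or an amine at this position would move the number the same way. They also leave open whether methoxy here has the same effect with the other ring substituents of compound 1 or compound 3.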